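A few compounds are considered here, and "the series" means these few. Any claim that something is new, unique, unknown or untested is made for them only; others in the source may bear on it.

In an ADME assay on KB cells (Homo sapiens) for cytotoxicity, read by MTT assay, with a stated time of 72 h (on this read-out lower numbers stand for stronger inhibition and higher numbers for weaker inhibition), compound 1 `C=CCOc1cc(C2=C(c3cc(OC)c(OC)c(OC)c3)C(=O)C(O)C2)ccc1OC` gives > 100 ug/mL, which is a limit of the assay and not a number. Compound 3 `COc1ccc(C2=C(c3cc(OC)c(OC)c(OC)c3)CC(O[SiH2]C(C)(C)C)C2=O)cc1[N+](=O)[O-]` gives > 100 ug/mL, again a limit. Compound 2 `COc1ccc(OC)c(C2=C(c3cc(OC)c(OC)c(OC)c3)C(=O)CC2O[SiH2]C(C)(C)C)c1` does return a number, 10 ug/mL. Compound 1 therefore stands at the limit of > 100 ug/mL in this assay, at which 2 of the 3 values shown sit. Compound 4 `COc1ccc(C2=C(c3cc(OC)c(OC)c(OC)c3)C(=O)C(O)C2)cc1OC(C)C` differs from it by one change, (isopropyl in place of allyl on an oxygen on an aromatic ring), which is isopropyl in place of allyl on an oxygen on an aromatic ring. Within the data shown here, no measured pair shows this change directly. In this assay, the estimated step of a number no higher from compound 1 to compound 4 (the limit leaves the size open) is expected to stay within the usual scatter, with no clear direction. For compound 4, the expected value is 100 ug/mL, with an estimated range from 30 ug/mL to 200 ug/mL.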

Compound 4, half-maximal inhibitory concentration: > 100 ug/mL
Compound 4: a limit, no number; the forecaster's own chance of this, stated with the estimate: 60%; the middle value lies on the limit itself.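

Among these compounds, compound 4 gives > 100 ug/mL, a limit and not a number, so no step from compound 1 to compound 4 can be read, since compound 1 sits at a limit as well. What the compounds shown leave open is how isopropyl and allyl on that oxygen compare in this assay: the limit of > 100 ug/mL in this assay, at which 3 of the 4 values shown sit.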